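The compounds below may be only part of what the source reports. "The series", "measured", "known", "first", "only" and "open" are said of these compounds alone.

The study centers on a functional assay (aorta) with Oryctolagus cuniculus as the target; a lower number here means tighter binding, a higher number weaker binding. Compound 1, `COc1cc(C(C)=O)ccc1OCCCN1CCC(C(C(N)=O)(c2ccc(F)cc2)c2ccc(F)cc2)CC1`, gives 25.1 nM in this assay. Compound 2, `Fc1ccc(OCCCN2CCC(C(c3ccc(F)cc3)c3ccc(F)cc3)CC2)cc1`, gives 1.26 nM in this assay and thus has the lowest number of the two, with compound 1 standing a step above it that lies beyond the scatter. Within the data shown here, no step between compounds differing in a single place has been measured, so nothing is known here about how one small change moves the number.

Compound 3, `Fc1ccc(C(c2ccc(F)cc2)C2CCN(CCCCc3ccccc3)CC2)cc1`, has not yet been measured. It differs from compound 2 in one place: benzyl in place of 4-fluorophenoxy on a saturated chain carbon, three bonds along the chain from an amine nitrogen in a ring. Among the measured compounds shown here, with no measured single-place step to lean on, the expected size of the change is modest: a small rise in the number, close to the edge of the scatter, is expected as a 2.4-fold higher number from compound 2 to compound 3 (0.38 log units; beyond the scatter). On that basis compound 3 is estimated at 3 nM in this assay, with a range from 0.8 nM to 12 nM.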

Compound 3, dissociation constant: 2.51 nM
Beside the measured number, compound 3's estimate is 1.2-fold (0.08 log units) above it; the measured number falls inside the stated range.
By their numbers in this assay, from the lowest: compounds 2 and 3 (each within the scatter of the next); then compound 1.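

In this assay, among these compounds, the first single-place step reads a 2.0-fold higher number from compound 2 to compound 3 (0.30 log units; within the scatter) and thus gives a direct view of this position, on a saturated chain carbon, three bonds along the chain from an amine nitrogen in a ring. Benzyl in place of 4-fluorophenoxy takes away the oxygen, the fluorine and the one hydrogen-bond acceptor of the leaving group, yet the numbers of compound 2 and compound 3 remain within the scatter of each other. Nothing measured here offers an explanation for this result.

The oxygen and the fluorine change together in this step, so a phenoxy or a 4-fluorobenzyl group would be needed to separate them. On these data alone, how this position responds to a carboxylic acid, an amine or a longer chain remains open.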